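A few compounds are considered here, and "the series" means these few. Any claim that something is new, unique, unknown or untested is made for them only; others in the source may bear on it.

Measured compounds:
- compound 1 `COc1cc(-c2nnc(SCC(=O)Nc3ccccc3C)n2N)cc(OC)c1OC`: > 100000 nM
- compound 2 `COc1cc(-c2nnc(SCC(=O)NCc3ccc(Cl)cc3)n2N)cc(OC)c1OC`: > 100000 nM

In a functional assay on HepG2 cells (Homo sapiens) for antiproliferative activity, read by MTT assay, with a stated time of 48 h (on this read-out higher numbers stand for weaker inhibition and lower numbers for stronger inhibition), compound 1 gives > 100000 nM, which is a limit of the assay and not a number. In this assay compound 2 likewise gives > 100000 nM, again a limit rather than a measured number. So compound 2 stands at the edge of what the assay reports, with no exact value. For the measured compounds named here, the only measured step, a step that the two limits leave unreadable from compound 1 to compound 2, cannot be sized, because the limit of > 100000 nM in this assay, at which 2 of the 2 values shown sit, places both of its ends at the same limit.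

Compound 3 `COc1cc(-c2nnc(SCC(=O)NCc3ccc(C)cc3)n2N)cc(OC)c1OC` differs from compound 2 by methyl in place of chloro on an aromatic carbon. No measured step covers this change, since the one step shown is unreadable in both size and direction. With compound 2 at the limit, there is no number from which a change could be measured, and the expectation for compound 3 rests only on compound 2 giving > 100000 nM.

For compound 3 the estimate in this assay is therefore 200000 nM, with a range from 50000 nM to 1000000 nM. The expected step that the limit leaves unreadable from compound 2 to compound 3 means no change beyond the scatter is anticipated, and most likely another limit.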

Compound 3, half-maximal inhibitory concentration: > 100000 nM
Compound 3: no number, only a limit (the forecaster's own chance of this, stated with the estimate: 80%); the middle value does not contradict the limit.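

In this assay compound 3 gives > 100000 nM as a limit of the assay and not a number. For the compounds shown here, no step among compound 1, compound 2 and compound 3 can be read, because all three stop at the same limit: the limit of > 100000 nM in this assay, at which 3 of the 3 values shown sit. The compounds shown leave open how strongly any of them acts on these cells, and whether methyl in place of chloro changes that at all.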